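A few compounds are considered here, and "the series" means these few. Any claim that something is new, unique, unknown or untested is made for them only; others in the source may bear on it.

Compound 1 `COc1ccc(C(=O)c2cc(C)ccc2OCC(=O)NNC(=O)c2cc3ccccc3oc2=O)cc1`, compound 2 `Cc1ccc(OCC(=O)NNC(=O)c2cc3ccccc3oc2=O)c(C(=O)c2ccccc2)c1` and compound 3 `Cc1ccc(OCC(=O)NNC(=O)c2cc3ccccc3oc2=O)c(C(=O)c2ccc(F)cc2)c1` share one core and differ only in a single substituent on one aromatic ring. In a functional assay on Ehrlich cells (Mus musculus) for cytotoxicity, read by MTT assay, with a stated time of 48 h (on this read-out higher numbers stand for weaker inhibition and lower numbers for stronger inhibition), compound 1 gives 38400 nM, compound 2 gives 78400 nM and compound 3 gives 39700 nM. Within the data shown here, the one step that clears the scatter is a 2.0-fold higher number from compound 1 to compound 2 (0.31 log units; beyond the scatter); the steps of a 1.0-fold higher number from compound 1 to compound 3 (0.01 log units; within the scatter) and a 2.0-fold lower number from compound 2 to compound 3 (0.30 log units; within the scatter) do not, so the number for compound 3 cannot be told apart from either neighbour and lies in the middle of the three.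

Compound 4 `Cc1ccc(C(=O)c2cc(C)ccc2OCC(=O)NNC(=O)c2cc3ccccc3oc2=O)cc1` follows from compound 3 by methyl in place of fluoro on an aromatic carbon. Among the measured compounds shown here, the steps that bear on this position, a 1.0-fold higher number from compound 1 to compound 3 (0.01 log units; within the scatter) and a 2.0-fold lower number from compound 2 to compound 3 (0.30 log units; within the scatter), both stay within the scatter, and the only step beyond it, a 2.0-fold higher number from compound 1 to compound 2 (0.31 log units; beyond the scatter), is modest; the data hold no step for methyl itself at this position. Compound 4 is therefore expected to show a 1.1-fold higher number from compound 3 to compound 4 (0.02 log units; within the scatter) in this assay, that is no change beyond the scatter. The estimate for compound 4 in this assay is 42000 nM, with a range of 18000 nM to 95000 nM.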

Compound 4, half-maximal inhibitory concentration: 78100 nM
For compound 4 the middle estimate is 1.9-fold (0.27 log units) below the measured one; measured number inside the range.
By their numbers in this assay, from the lowest: compounds 1, 3, 4 and 2 (each within the scatter of the next, the first and the last beyond it).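

Methyl on this aromatic carbon, para to a large group, gives the first reading of a carbon substituent here, and in this assay it cannot be told apart from fluoro (a 2.0-fold higher number from compound 3 to compound 4 (0.29 log units; within the scatter)) or from hydrogen (a 1.0-fold lower number from compound 2 to compound 4 (0.00 log units; within the scatter)). Against methoxy the same methyl shows a 2.0-fold higher number from compound 1 to compound 4 (0.31 log units; beyond the scatter), a modest step of the same kind as the one from methoxy to hydrogen, so compounds 2 and 4 both stand apart from compound 1, while compound 3 stands apart from none of the others. No data here bear on what lies behind these steps.

On these data alone, whether an amine, a carboxylic acid or a longer chain at this position would give a larger step remains open. Also open, as far as these compounds go, is whether the modest separation from methoxy would hold up in repeated measurements.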